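The source may hold more compounds than are shown below. What is called first, only, known or untested is meant among the compounds shown, and "the series" means these compounds.

In an ADME assay on BJ cells (Homo sapiens), read by MTT assay, with a stated time of 72 h (on this read-out lower numbers stand for stronger inhibition and higher numbers for weaker inhibition), compound 1 `Nc1nc(N)c2c(-c3ccco3)cn([C@@H]3O[C@H](CO)[C@@H](O)[C@H]3O)c2n1` gives > 100000 nM as a limit and not a number. Compound 2 `Nc1nc(N)c2c(-c3cc4ccccc4o3)cn([C@@H]3O[C@H](CO)[C@@H](O)[C@H]3O)c2n1` gives > 100000 nM as a limit too. Compound 3 `Cc1nc(N)c2c(-c3ccco3)cn([C@@H]3O[C@H](CO)[C@@H](O)[C@H]3O)c2n1` gives > 100000 nM as a limit as well, so it has no number of its own. Among the measured compounds shown here, the series so far stands at the limit of > 100000 nM in this assay, at which 3 of the 3 values shown sit, with no compound set apart. Compound 4 `Cc1nc(N)c2c(-c3ccoc3)cn([C@@H]3O[C@H](CO)[C@@H](O)[C@H]3O)c2n1` carries furan-3-yl in place of furan-2-yl on an aromatic carbon, and furan-3-yl in place of furan-2-yl on an aromatic carbon is the whole change. For the measured compounds named here, two measured steps bear on it: a step that the two limits leave unreadable from compound 1 to compound 2 and a step that the two limits leave unreadable from compound 1 to compound 3 offer no size to carry over. No step beyond the scatter is therefore expected in this assay and the expected move is a number no higher from compound 3 to compound 4 (the limit leaves the size open) with no direction to call. For compound 4 the estimated value is 100000 nM with an expected range of 40000 nM to 200000 nM and a report as a limit alone is likely.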

Compound 4, half-maximal inhibitory concentration: > 100000 nM
Compound 4: only a limit was reported (the forecaster's own chance of this, stated with the estimate: 85%); the middle value lies on the limit itself.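

Among the compounds shown here, compound 3 and compound 4 are both reported only as limits, so no step between them can be read in this assay. Whether any change to the shared core gives a measurable value stays open, with every value shown at one limit: the limit of > 100000 nM in this assay, at which 4 of the 4 values shown sit.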